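Swapping the Amide Aryl Group: Compound 2 to Compound 4

A few compounds are considered here, and "the series" means these few. Any claim that something is new, unique, unknown or untested is made for them only; others in the source may bear on it.

compound 1, `C=C(CC)C(=O)c1ccc(OCC(=O)Nc2ccc(C(=O)NC(CCC(=O)OCC)C(=O)OCC)cc2)c(Cl)c1Cl`: 2100 nM
compound 2, `C=C(CC)C(=O)c1ccc(OCC(=O)Nc2ccc3nc[nH]c3c2)c(Cl)c1Cl`: 3200 nM
compound 3, `C=C(CC)C(=O)c1ccc(OCC(=O)Nc2ccc(Cl)c(C(=O)O)c2)c(Cl)c1Cl`: 15900 nM

In a functional assay on CLL cells (Homo sapiens) for cytotoxicity, read by MTT assay, with a stated time of 48 h (a lower number here means that less compound is needed, a higher number that more compound is needed for the effect), compound 2 gives 3200 nM, the second highest of the three numbers. Compound 1 sits within the scatter of compound 2, whereas compound 3 lies beyond the scatter, with the higher number. Compound 4, `C=C(CC)C(=O)c1ccc(OCC(=O)Nc2ccc(C(N)=O)cc2)c(Cl)c1Cl`, has not been measured. It differs from compound 2 in one place: 4-carbamoylphenyl in place of 1H-benzimidazol-6-yl on an amide-type nitrogen. For the measured compounds named here, no step between measured compounds is available to anchor the change. Because compound 1, which also carries an amide substituent on the phenyl ring, gives 2100 nM, the step from compound 2 to compound 4 is expected to be a 1.3-fold lower number from compound 2 to compound 4 (0.11 log units; within the scatter), a slightly lower number but not beyond the scatter. Compound 4 is therefore estimated to give 2500 nM in this assay, with a range from 1000 nM to 7000 nM.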

Compound 4, half-maximal effective concentration: 3700 nM
Compound 4: the middle estimate sits 1.5-fold (0.17 log units) below what was measured; the measured number falls inside the stated range.
By their numbers in this assay, from the lowest: compounds 1, 2 and 4 (each within the scatter of the next); then compound 3.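

For the compounds shown here, on the amide-type nitrogen, 4-carbamoylphenyl in place of 1H-benzimidazol-6-yl gives a 1.2-fold higher number from compound 2 to compound 4 (0.06 log units; within the scatter) in this assay, the only step at this position that can be read. This place therefore accepts a single six-membered aromatic ring of carbon only, carrying a carbamoyl group, in place of the fused pair of aromatic rings, with the step staying within the scatter. No available evidence bears on this result. Still open, from the compounds shown here alone, is whether a nitrile or an amine in place of the carbamoyl group would also stay within the scatter of compound 4.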